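The compounds below may be only part of what the source reports. "The series", "measured", "known", "first", "only" and "open" are said of these compounds alone.

Working notes on the series. The shared core is seen in compound 1 `COc1ccccc1C#Cc1nc2c(s1)C(=O)NCC2`, compound 2 `CN1CCc2nc(C#Cc3cccc(F)c3)sc2C1` and compound 3 `O=C(C1CC1)N1CCc2nc(C#Cc3ccccc3)sc2C1`. In an assay on HEK293 cells for negative allosteric modulation of metabotropic glutamate receptor 5 (Homo sapiens), read by FLIPR, with a stated time of 1 h (on this read-out lower numbers stand for stronger inhibition and higher numbers for weaker inhibition), compound 1 gives only a limit of the assay, > 10000 nM. Compound 2 likewise returns a limit in this assay, > 10000 nM. Among the measured compounds shown here, compound 3 is the one compound with a number in this assay, 290 nM, while the other two values sit at the limit of > 10000 nM in this assay, at which 2 of the 3 values shown sit. For the measured compounds named here, no step between two measured compounds differing in a single place is available, so the series so far gives no guide to how the substituent on the amide carbonyl moves the read-out.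

Compound 4 `CC1CCCC(C(=O)N2CCc3nc(C#Cc4ccccc4)sc3C2)C1` keeps the core of compound 3 and changes only that substituent: 3-methylcyclohexyl in place of cyclopropyl on a carbonyl carbon. Going by the values given here, with no measured step to lean on, the step from compound 3 to compound 4 in this assay is expected to stay within the scatter or to move only modestly in either direction, a 1.0-fold higher number from compound 3 to compound 4 (0.01 log units; within the scatter). For compound 4 the estimate in this assay is 300 nM, with a range from 60 nM to 1500 nM. Among the compounds with values here, the range is kept wide since compound 3 at 290 nM is the only number in this assay from which to start.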

Compound 4, half-maximal inhibitory concentration: > 10000 nM
Compound 4 gave a limit, no number; the forecaster's own chance of this, stated with the estimate: 10%; at least 33-fold (1.52 log units) between middle value and limit.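

In this assay the substituent on a carbonyl carbon whose other neighbours are amide-type nitrogen in a ring now has its first measured step: 3-methylcyclohexyl in place of cyclopropyl, with the rest of compound 3 unchanged, gives an at least 34-fold higher number from compound 3 to compound 4 (1.53 log units; beyond the scatter). The read-out of this series therefore responds strongly to this one position, and the change from a three-membered to a six-membered carbon ring bearing a methyl group is not tolerated within the range of the assay. Compound 4 gives a limit of the assay, not a number, so compound 3 remains the only compound in the series with a number, and the values shown gather at one end: the limit of > 10000 nM in this assay, at which 3 of the 4 values shown sit.

Among the compounds shown here, the single step leaves open whether the larger ring or its methyl group carries the change, and how far the true value of compound 4 lies from the limit cannot be read. Plain cyclohexyl, cyclobutyl or a short chain such as isopropyl on the same carbonyl carbon would separate these, and a methoxymethyl group or an amine there would extend the comparison beyond carbon-only substituents.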